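This account rests on a few compounds, and the source may have more. Where it says the series, first, only, none or still open, it means among the compounds named here.

Compound 1, `CC(=O)Oc1cccc2cc(-c3cccs3)c(=O)oc12`: in an assay on CHO cells for displacement of a labelled ligand from adenosine receptor A1 (Homo sapiens) (on this read-out lower numbers stand for stronger inhibition and higher numbers for weaker inhibition), compound 1 gives > 100000 nM, which is a limit of the assay and not a number.
Compound 2, `CC(=O)Oc1ccc2cc(-c3ccsc3)c(=O)oc2c1OC(C)=O`: in this assay compound 2 gives > 100000 nM, again a limit rather than a number.
Compound 3, `O=c1oc2c(O)cccc2cc1-c1cccs1`: in this assay compound 3 gives 3360 nM.

Compound 3 therefore holds the only number shown in this assay; the two other values sit at the limit of the assay (the limit of > 100000 nM in this assay, at which 2 of the 3 values shown sit), so nothing more can be said of their order. For the measured compounds named here, the single measured step, an at least 29-fold lower number from compound 1 to compound 3 (1.47 log units; beyond the scatter), removes an acetyl group from the oxygen on the aromatic ring and leaves a hydroxy group there.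

Compound 4, `O=c1oc2c(O)c(O)ccc2cc1-c1cccs1`, is not yet measured. It differs from compound 3 by hydroxy in place of hydrogen on an aromatic carbon. Going by the values given here, no measured pair repeats this change: the one available step, an at least 29-fold lower number from compound 1 to compound 3 (1.47 log units; beyond the scatter), concerns the hydroxy group already present rather than a second one, and compound 2, which carries acetyl on both oxygens, shows only a limit. The change is small, adding a hydroxy group, and with nothing among the compounds shown to weigh it either way the expectation is of a step no larger than the scatter, a 1.2-fold higher number from compound 3 to compound 4 (0.08 log units; within the scatter). Compound 4 is accordingly estimated at 4000 nM, between 1000 nM and 20000 nM, in this assay.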

Compound 4, inhibition constant: 3230 nM
For compound 4 the middle estimate is 1.2-fold (0.09 log units) above the measured one; low and high end bracket the measured number.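

Placing hydroxy in place of hydrogen on this aromatic carbon, ortho to a hydroxy group, gives a 1.0-fold lower number from compound 3 to compound 4 (0.02 log units; within the scatter), so the two compounds cannot be told apart in this assay. For the compounds shown here, the earlier compounds spoke only about the oxygen that already carried a substituent, where the step was an at least 29-fold lower number from compound 1 to compound 3 (1.47 log units; beyond the scatter); compound 4 is the first to report on this other position of the ring, and it shows that a second hydroxy group can stand there with the number staying within the scatter. Among the compounds shown, then, the large step goes with the acetyl group on the oxygen, and the added hydroxy group brings no step beyond the scatter.

Going by these compounds, whether another group on this carbon, such as an amine, a methoxy group or a carboxylic acid, would give a different number stays open. Compound 2 gives > 100000 nM, which is a limit and not a number, and that compound also differs in more than one place, so it does not tell what acetyl on this oxygen would do: the limit of > 100000 nM in this assay, at which 2 of the 4 values shown sit.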